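The compounds below may be only part of what the source reports. "The series", "measured", "known", "first", "only" and "open" are said of these compounds alone.

Working notes on the series: compound 1 (`COc1ccc(-c2ccc(OCc3cc(C(=O)NS(=O)(=O)c4ccccc4)oc3C)cc2)c(C)c1`) and compound 2 (`COc1ccc(-c2ccc(OCc3cc(C(=O)NS(=O)(=O)c4ccccc4)oc3C)cc2)cc1`) have both been read in a physicochemical assay for solubility, in phosphate buffer, with a stated time of 24 h, at pH 7.4; on this read-out higher numbers stand for higher solubility and lower numbers for lower solubility. There compound 1 gives 20 ug/mL and compound 2 gives 11 ug/mL. Within the data shown here, compound 2 thus has compound 1 as its only neighbour, and the two values lie within the scatter of each other. Next comes compound 3 (`COc1ccc(-c2ccc(OCc3cc(C(=O)NS(=O)(=O)c4ccccc4)oc3C)cc2)nc1`), with 5-methoxypyridin-2-yl in place of 4-methoxyphenyl on an aromatic carbon. Among the measured compounds shown here, only one measured step bears on this, and only loosely: a 1.8-fold lower number from compound 1 to compound 2 (0.26 log units; within the scatter), with hydrogen in place of methyl on an aromatic carbon. For the measured compounds named here, no measured step covers a change of this kind, so this assay offers no direct guide. A small upward move, not clearly beyond the scatter, is expected: a 1.6-fold higher number from compound 2 to compound 3 (0.21 log units; within the scatter). The estimate for compound 3 is 18 ug/mL, with an expected range of 7 ug/mL to 50 ug/mL.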

Compound 3, solubility: 30 ug/mL
Compound 3: middle estimate off by 1.7-fold (0.22 log units), on the low side, and the stated range covers the measured number.
By their numbers in this assay, from the lowest: compounds 2, 1 and 3 (each within the scatter of the next, the first and the last beyond it).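

In this assay, 5-methoxypyridin-2-yl in place of 4-methoxyphenyl at this position gives the only step shown that lies beyond the scatter: a 2.7-fold higher number from compound 2 to compound 3 (0.44 log units; beyond the scatter), a modest move resting on this single pair. Set against 4-methoxy-2-methylphenyl at the same position, the same group gives a 1.5-fold higher number from compound 1 to compound 3 (0.18 log units; within the scatter), which stays within the scatter, so compound 1 and compound 3 cannot be separated on this read-out. Nothing measured on these compounds bears on the reason for the step.

Still open, as far as these compounds go, is whether a methyl group on the 5-methoxypyridin-2-yl group would shift the number for compound 3. Also open, from the compounds shown here alone, is how an amine or a carboxylic acid in place of the methoxy group would read in this assay.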